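Chalcone series on a shared core: one swap repeated

The source may hold more compounds than are shown below. What is called first, only, known or untested is meant among the compounds shown, and "the series" means these compounds.

Compound 1 `COc1ccc(C(=O)/C=C/c2cc(-c3ccc(OC)c(OC)c3)n3nc(-c4ccccc4)cc3n2)cc1OC` carries a 3,4-dimethoxyphenyl on the carbonyl carbon and is the reference of the set. In a functional assay on A549 cells (Homo sapiens) for antiproliferative activity, read by MTT assay, with a stated time of 24 h (on this read-out lower numbers stand for stronger inhibition and higher numbers for weaker inhibition), compound 1 gives 3900 nM. Compound 2 `COc1ccc(-c2cc(/C=C/C(=O)c3ccc(Cl)cc3)nc3cc(-c4ccccc4)nn23)cc1OC` differs from compound 1 by 4-chlorophenyl in place of 3,4-dimethoxyphenyl on a carbonyl carbon; in this assay compound 2 gives 15400 nM, a step of a 3.9-fold higher number from compound 1 to compound 2 (0.60 log units; beyond the scatter). Compound 3 `COc1ccc(C(=O)/C=C/c2cc(-c3cc(OC)c(OC)c(OC)c3)n3nc(-c4ccccc4)cc3n2)cc1OC` differs from compound 1 by methoxy in place of hydrogen on an aromatic carbon; in this assay compound 3 gives 17800 nM, a step of a 4.6-fold higher number from compound 1 to compound 3 (0.66 log units; beyond the scatter). Compound 2 and compound 3 lie within the scatter of one another.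

Compound 4 `COc1cc(-c2cc(/C=C/C(=O)c3ccc(Cl)cc3)nc3cc(-c4ccccc4)nn23)cc(OC)c1OC` is not yet measured. It differs from compound 3 by 4-chlorophenyl in place of 3,4-dimethoxyphenyl on a carbonyl carbon, the same change as that from compound 1 to compound 2, and the two place descriptions agree word for word. The cores of the two pairs differ by methoxy in place of hydrogen on an aromatic carbon.

Going by the values given here, the step from compound 3 to compound 4 in this assay is expected to be a 3.1-fold higher number from compound 3 to compound 4 (0.49 log units; beyond the scatter), resting on the single earlier instance, a 3.9-fold higher number from compound 1 to compound 2 (0.60 log units; beyond the scatter), with no second example to test whether it transfers to the trimethoxy core. Compound 4 is therefore estimated at 55000 nM, with a range of 20000 nM to 150000 nM.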

Compound 4, half-maximal inhibitory concentration: 15500 nM
The estimate for compound 4 lay 3.5-fold (0.55 log units) above the measured number, and the stated range ends above it.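

In this assay the change to 4-chlorophenyl on the carbonyl carbon gives a 1.1-fold lower number from compound 3 to compound 4 (0.06 log units; within the scatter), so the step seen on the core of compound 1 does not carry over to the core of compound 3: the same change on two cores in this assay, a 3.9-fold higher number (0.60 log units; beyond the scatter) from compound 1 to compound 2 and a 1.1-fold lower number (0.06 log units; within the scatter) from compound 3 to compound 4, 4.5-fold (0.66 log units) apart, beyond the scatter of two such steps

Read the other way, the added methoxy gives a 1.0-fold higher number from compound 2 to compound 4 (0.00 log units; within the scatter), so its step also depends on the group on the carbonyl carbon: the same change on two cores in this assay, a 4.6-fold higher number (0.66 log units; beyond the scatter) from compound 1 to compound 3 and a 1.0-fold higher number (0.00 log units; within the scatter) from compound 2 to compound 4, 4.5-fold (0.66 log units) apart, beyond the scatter of two such steps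

Compound 2, compound 3 and compound 4 lie within the scatter of one another, which shows the two changes do not add up in this set, but these four compounds do not show why, or whether the same holds for any other pair of groups.

Open, on these data alone, is whether the step returns with another group on the carbonyl carbon, such as an unsubstituted phenyl or a 4-aminophenyl. Also open, as far as these compounds go, is how a single methoxy, or a carboxylic acid, in place of the dimethoxyphenyl or trimethoxyphenyl group on the shared core would behave.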